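Macrocyclic series: quinoline substituent and tolerated concentration

This account rests on a few compounds, and the source may have more. Where it says the series, first, only, none or still open, it means among the compounds named here.

Measured compounds and values:
Compound 1 `COc1ccc2c(O[C@H]3C[C@H]4C(=O)N(C)CCCC/C=C/[C@@H]5C[C@@]5(C(=O)NS(=O)(=O)C5(C)CC5)NC(=O)N4C3)cc(-c3nc(C(F)(F)F)cs3)nc2c1C` gives 75000 nM
Compound 2 `COc1ccc2c(O[C@H]3C[C@H]4C(=O)N(C)CCCC/C=C/[C@@H]5C[C@@]5(C(=O)NS(=O)(=O)C5CC5)NC(=O)N4C3)cc(-c3nc(C4CC4)cs3)nc2c1Cl` gives 31300 nM
Compound 3 `COc1ccc2c(O[C@H]3C[C@H]4C(=O)N(C)CCCC/C=C/[C@@H]5C[C@@]5(C(=O)NS(=O)(=O)C5(C)CC5)NC(=O)N4C3)cc(-c3nc(C4CCC4)cs3)nc2c1Cl` gives 75000 nM

All three numbers come from an ADME assay on Huh-7 cells (Homo sapiens) for cytotoxicity, read by colorimetric assay; a lower number here means that less compound is tolerated, a higher number that more compound is tolerated. Compound 1 and compound 3 stand level at the digits shown, and together they are the highest numbers of the three. Compound 2 is the one that differs: its number is lower than that of compound 1, and the gap lies beyond the scatter. Within the data shown here, no pair among the measured compounds differs in only one place, so no single step can be read off; the three compounds differ from one another at the sulfonamide ring, at the group on the core and at the thiazole substituent at the same time.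

Compound 4 `COc1ccc2c(O[C@H]3C[C@H]4C(=O)N(C)CCCC/C=C/[C@@H]5C[C@@]5(C(=O)NS(=O)(=O)C5(C)CC5)NC(=O)N4C3)cc(-n3cc(C(C)C)cn3)nc2c1C` is the next compound to be read in this assay. It keeps the core and the sulfonamide of compound 1 and changes one thing: 4-isopropyl-1H-pyrazol-1-yl in place of 4-(trifluoromethyl)-1,3-thiazol-2-yl on an aromatic carbon of the core.

Among the measured compounds shown here, with no step of this kind measured here, the expectation for compound 4 can rest only on compound 1, whose value 75000 nM sits at the top of the range seen so far. The expected step of a 1.3-fold lower number from compound 1 to compound 4 (0.10 log units; within the scatter) is not beyond the scatter. For compound 4 a value of 60000 nM is estimated, in the range 25000 nM to 100000 nM.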

Compound 4, half-maximal cytotoxic concentration: 9610 nM
Compound 4: middle estimate off by 6.2-fold (0.80 log units), on the high side; measured number below the stated range.
By their numbers in this assay, from the lowest: compound 4; then compound 2; then compounds 1 and 3 (each within the scatter of the next).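

In this assay, among these compounds, the exchange of 4-(trifluoromethyl)-1,3-thiazol-2-yl for 4-isopropyl-1H-pyrazol-1-yl gives a 7.8-fold lower number from compound 1 to compound 4 (0.89 log units; beyond the scatter), the first step that can be read at a single place. The earlier compounds shown here differed in several places at once and could assign nothing to this aromatic carbon of the core; this step shows that the group there can by itself move the tolerated concentration beyond the scatter, even though both groups count as one five-membered aromatic ring with 2 hetero atoms, 0 hydrogen-bond donors, 2 hydrogen-bond acceptors and no net charge. Nothing at hand explains the size of this step.

As far as these compounds go, the step changes the ring and its substituent together, so the share of each stays open; a 4-isopropyl-1,3-thiazol-2-yl or a 4-(trifluoromethyl)-1H-pyrazol-1-yl group at the same place would separate the two. Also open, from the compounds shown here alone, is whether the step holds with the other sulfonamide ring and the other group on the core seen, and how an amine or a carboxylic acid on the pyrazole would read in this assay.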